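A few compounds are considered here, and "the series" means these few. Any claim that something is new, unique, unknown or untested is made for them only; others in the source may bear on it.

Series notes. Compound 3 `COc1ccc(-c2cc3ccccc3nc2/C=C/C(=O)c2cccs2)cc1` carries a thiophen-2-yl on the carbonyl carbon; in a functional assay on H184B5F5/M10 cells (Homo sapiens) for antiproliferative activity, read by XTT assay, with a stated time of 72 h (on this read-out higher numbers stand for weaker inhibition and lower numbers for stronger inhibition), compound 3 gives 7030 nM. Compound 2 `COc1ccc(-c2cc3ccccc3nc2/C=C/C(=O)c2ccc([N+](=O)[O-])cc2)cc1` gives 6100 nM in this assay, and the pair read a 1.2-fold higher number from compound 2 to compound 3 (0.06 log units; within the scatter), so compound 3 stands alongside compound 2 rather than apart from it. Compound 1 `COc1ccc(C(=O)/C=C/c2nc3ccccc3cc2-c2ccc(OC)cc2)cc1` returns only a limit in this assay, > 10000 nM, that is the limit of > 10000 nM in this assay, at which 1 of the 3 values shown sits. Against it the steps of an at least 1.6-fold lower number from compound 1 to compound 2 (0.21 log units; that floor lies within the scatter) and an at least 1.4-fold lower number from compound 1 to compound 3 (0.15 log units; that floor lies within the scatter) have floors inside the scatter. Compound 4 `COc1ccc(-c2cc3ccccc3nc2/C=C/C(=O)c2ccc(Br)s2)cc1` differs from compound 3 by bromo in place of hydrogen on an aromatic carbon. For the measured compounds named here, no measured step touches a substituent on the thiophen-2-yl; the measured steps all exchange the aryl on the carbonyl and stay within scatter, so in this assay no step beyond the scatter is expected in either direction. The expected step is a 1.0-fold lower number from compound 3 to compound 4 (0.00 log units; within the scatter), and compound 4 is estimated at 7000 nM, range 3000 nM to 16000 nM.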

Compound 4, half-maximal inhibitory concentration: 9380 nM
Estimate against measurement, compound 4: 1.3-fold (0.13 log units) below; low and high end bracket the measured number.
By their numbers in this assay, from the lowest: compounds 2, 3 and 4 (each within the scatter of the next). At a limit, above all of these: compound 1.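

Bromo next to the ring sulfur is the only change shown on the thiophen-2-yl itself, and in this assay it gives a 1.3-fold higher number from compound 3 to compound 4 (0.13 log units; within the scatter), so this position takes bromo without a step beyond the scatter. The 5-bromothiophen-2-yl also stays within the scatter of the 4-nitrophenyl, with a 1.5-fold higher number from compound 2 to compound 4 (0.19 log units; within the scatter). The step of an at least 1.0-fold lower number from compound 1 to compound 4 (0.02 log units; that floor lies within the scatter) has only a floor, and one of its ends is a limit: the limit of > 10000 nM in this assay, at which 1 of the 4 values shown sits.

On these data alone, whether an amine, a carboxylic acid or a methyl on this carbon would move the number beyond the scatter stays open. So does whether any group on the carbonyl carbon reaches a clearly lower number than the aryls shown.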